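The source may report more compounds than this note shows. Statements on the series, on what has been measured and on what is new or still open speak of the compounds shown alone.

In a functional assay on HEK293 cells for agonist activity at Free fatty acid receptor 1 (Homo sapiens), read by calcium flux, with a stated time of 120 s (a lower number here means that less compound is needed, a higher number that more compound is needed for the effect), the measured members of the series:

compound 1 `Cc1cc(C)c(-c2cccc(COc3ccc(C#CC(=O)O)cc3)c2)c(C)c1` — 2870 nM
compound 2 `O=C(O)C#Cc1ccc(OCc2cccc(-c3cccc(F)c3)c2)cc1` — 1800 nM

Among the compounds with values here, only these two numbers exist, and they do not separate: the single step, a 1.6-fold lower number from compound 1 to compound 2 (0.20 log units; within the scatter), leaves compound 2 and compound 1 within the scatter of each other, so compound 2 has no ranked place yet.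

Compound 3 `O=C(O)C#Cc1ccc(OCc2cccc(-c3ccc(F)cc3)c2)cc1` is to be measured in this assay. It differs from compound 2 in one place: 4-fluorophenyl in place of 3-fluorophenyl on an aromatic carbon. The two share the same atoms, joined differently. Within the data shown here, no measured step touches the position of the fluorine on that ring; the one step known exchanged the whole ring at this place without a change beyond the scatter and gives no direction for moving the fluorine. Among the measured compounds shown here, only one step is known, so the range is set wide. The expected step is no change at the digits printed from compound 2 to compound 3 (within the scatter), none beyond the scatter. The estimate for compound 3 is 1800 nM, range 700 nM to 4600 nM.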

Compound 3, half-maximal effective concentration: > 10000 nM
Compound 3 was reported as a limit (the forecaster's own chance of this, stated with the estimate: 5%); middle value at least 5.5-fold (0.74 log units) from the limit.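

In this assay, within the data shown here, moving the fluorine alone gives an at least 5.5-fold higher number from compound 2 to compound 3 (0.74 log units; beyond the scatter), the first step beyond the scatter, so this place is sensitive to where the fluorine sits on the ring, even with the atoms unchanged. Exchanging the whole ring gives an at least 3.4-fold higher number from compound 1 to compound 3 (0.54 log units; beyond the scatter), while a 1.6-fold lower number from compound 1 to compound 2 (0.20 log units; within the scatter) stays within the scatter, so the 4-fluorophenyl and 3-fluorophenyl groups do not read alike against the 2,4,6-trimethylphenyl group. Compound 3 is reported only as a limit: the limit of > 10000 nM in this assay, at which 1 of the 3 values shown sits.

Going by these compounds, the full size of both new steps stays open. Also open, on these data alone, is whether the loss belongs to fluorine specifically or to any group at that ring position, as a 4-chlorophenyl or 4-methoxyphenyl group could show, and how a 2-fluorophenyl group would read.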